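This account rests on a few compounds, and the source may have more. Where it says the series, first, only, none or still open, it means among the compounds named here.

Measured compounds:
compound 1, `COc1cc(OC(F)(F)F)cc(-c2ccc3c(c2)CC[C@H](CCc2nnn[nH]2)O3)c1F`, > 10000 nM
compound 2, `O=C(O)CC[C@H]1CCc2cc(-c3nc(OC4CCC4)ccc3F)ccc2O1`, > 10000 nM

Compound 1 stands at the limit of a functional assay on HEK293 cells for agonist activity at Free fatty acid receptor 1 (Homo sapiens), read by HTRF and inositol phosphate accumulation, with a stated time of 60 min; a lower number here means that less compound is needed, a higher number that more compound is needed for the effect: in this assay compound 1 gives > 10000 nM, a limit rather than a number. Compound 2 likewise gives only a limit, > 10000 nM. Both sit at the limit of > 10000 nM in this assay, at which 2 of the 2 values shown sit. Compound 3, `COc1cc(OC2CC2)cc(-c2ccc3c(c2)CC[C@H](CCc2nnn[nH]2)O3)c1F`, differs from compound 1 by cyclopropyl in place of trifluoromethyl on an oxygen on an aromatic ring. No step between measured compounds is shown, so no size can be read from the data. Compound 3 is expected to remain near the limit, the expected step that the limit leaves unreadable from compound 1 to compound 3 being none beyond the scatter. Compound 3 is estimated at 15000 nM, range 4000 nM to 60000 nM.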

Compound 3, half-maximal effective concentration: > 10000 nM
Compound 3: a limit, no number; the forecaster's own chance of this, stated with the estimate: 75%; the middle value is on the limit's open side.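

Compound 3, like compound 1, gives only a limit, so no step can be read between them: the limit of > 10000 nM in this assay, at which 3 of the 3 values shown sit. In this assay the compounds shown leave open how cyclopropyloxy compares with trifluoromethoxy, and which structures would give a number rather than a limit.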